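Aryl swap at one aromatic carbon: working notes

A few compounds are considered here, and "the series" means these few. Any claim that something is new, unique, unknown or untested is made for them only; others in the source may bear on it.

Measured so far:
Compound 1 `CS(=O)(=O)c1ccc(-c2cnc3[nH]cc(-c4nnc(-c5ccccn5)o4)c(=O)c3c2)cc1`: 34.3%
Compound 2 `CS(=O)(=O)c1ccc(-c2cnc3[nH]cc(-c4nnc(-c5ccc(Cl)cc5)o4)c(=O)c3c2)cc1`: 24.9%

Both numbers come from a functional assay on HCT-116 cells (Homo sapiens) for positive allosteric modulation, read by MTT assay, with stated times of 24 h and 48 h, tested at 2.5 uM; on this read-out higher numbers stand for more inhibition of growth at the one concentration tested and lower numbers for less inhibition of growth. Among the compounds with values here, compound 2 stands at the lower of the two values, but the only step so far, a number 9.4 percentage points lower from compound 1 to compound 2 (within the scatter), is within the scatter, so the two compounds cannot be ordered.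

Compound 3 `CS(=O)(=O)c1ccc(-c2cnc3[nH]cc(-c4nnc(-c5cccnc5)o4)c(=O)c3c2)cc1` is not yet measured. It differs from compound 2 in one place: pyridin-3-yl in place of 4-chlorophenyl on an aromatic carbon. Within the data shown here, the one measured step bears on this change, since it also exchanged a pyridyl for the 4-chlorophenyl at the same aromatic carbon, and it was small. On that basis no step beyond the scatter is expected for a number 5.1 percentage points higher from compound 2 to compound 3 (within the scatter), with a slight lean back toward the value of compound 1 because of a number 9.4 percentage points lower from compound 1 to compound 2 (within the scatter). The estimate for compound 3 in this assay is 30%, within a range from 18% to 42%.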

Compound 3, percent growth inhibition at one concentration: 28.6%
The estimate for compound 3 lay 1.4 percentage points above the measured number, within the range that was stated.
By their numbers in this assay, from the lowest: compounds 2, 3 and 1 (each within the scatter of the next).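

In this assay, pyridin-3-yl in place of 4-chlorophenyl gives a number 3.7 percentage points higher from compound 2 to compound 3 (within the scatter), and pyridin-3-yl in place of pyridin-2-yl gives a number 5.7 percentage points lower from compound 1 to compound 3 (within the scatter). Within the data shown here, the second step is the first comparison of two pyridyl groups at this aromatic carbon of the five-membered ring, and it shows that the two attachments cannot be told apart here; together with the first step, it leaves compound 1, compound 2 and compound 3 unordered. Nothing available explains these values or bears on the two changes.

All three compounds carry a six-membered aromatic ring at this carbon. Still open, from the compounds shown here alone, is whether an amine, a carboxylic acid or a longer alkyl chain at the same place would give a step beyond the scatter, and how a pyridin-4-yl group would compare.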